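Phenylsulfonyl for 4-methoxyphenoxy: compound 4

A few compounds are considered here, and "the series" means these few. Any claim that something is new, unique, unknown or untested is made for them only; others in the source may bear on it.

Compound 1 `COc1cc(C#N)ccc1OCCCN1CCC(C(c2ccc(F)cc2)c2ccc(F)cc2)CC1`: 2 nM
Compound 2 `Fc1ccc(C(c2ccc(F)cc2)C2CCN(CCCOc3ccc(Br)cc3)CC2)cc1`: 1.59 nM
Compound 3 `COc1ccc(OCCCN2CCC(C(c3ccc(F)cc3)c3ccc(F)cc3)CC2)cc1`: 2.51 nM

All three values come from a functional assay (aorta) with Oryctolagus cuniculus as the target; on this read-out lower numbers stand for tighter binding and higher numbers for weaker binding. Compound 3 stands within the scatter of both other compounds, with a 1.3-fold higher number from compound 1 to compound 3 (0.10 log units; within the scatter) and a 1.6-fold higher number from compound 2 to compound 3 (0.20 log units; within the scatter).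

The next compound is compound 4 `O=S(=O)(CCCN1CCC(C(c2ccc(F)cc2)c2ccc(F)cc2)CC1)c1ccccc1`. The change is phenylsulfonyl in place of 4-methoxyphenoxy on a saturated chain carbon, three bonds along the chain from an amine nitrogen in a ring.

The two steps into compound 3 bear on this only indirectly, as does a 1.3-fold lower number from compound 1 to compound 2 (0.10 log units; within the scatter). All three stay within the scatter, but each exchanges only groups on an oxygen on a saturated carbon or on an aromatic carbon. None replaces that oxygen, so the data hold no direct measure of this change, and a larger step cannot be ruled out.

A small step towards a higher number in this assay is therefore expected, held loosely. The expected step is a 1.6-fold higher number from compound 3 to compound 4 (0.20 log units; within the scatter). For compound 4 the estimated value is 4 nM, with an expected range of 1.2 nM to 15 nM.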

Compound 4, dissociation constant: 20 nM
Compound 4: middle estimate off by 5.0-fold (0.70 log units), on the low side, and the stated range ends below it.
By their numbers in this assay, from the lowest: compounds 2, 1 and 3 (each within the scatter of the next); then compound 4.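

In this assay, within the data shown here, the earlier exchanges touched only the aryl group on the oxygen and all stayed within the scatter, so this is the first change at this position to register beyond it: an 8.0-fold higher number from compound 3 to compound 4 (0.90 log units; beyond the scatter). The other two comparisons run the same way, a 13-fold higher number from compound 2 to compound 4 (1.10 log units; beyond the scatter) and a 10-fold higher number from compound 1 to compound 4 (1.00 log units; beyond the scatter), so among the compounds shown the phenylsulfonyl compound stands apart from all three aryloxy compounds, whichever ring substituents those carry. The position on the saturated chain carbon, three bonds along the chain from the amine nitrogen in the ring, therefore responds to this exchange even though the heavy-atom, aromatic-ring and hydrogen-bond-acceptor counts stay the same, and no measurement at hand accounts for the step.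

Compound 4 differs from the others both in the sulfonyl group replacing the oxygen and in carrying an unsubstituted ring, and the compounds shown leave open which of the two goes with the step. A plain phenoxy group and a 4-methoxyphenylsulfonyl group on the same chain would separate the two, while a benzoyl group or a longer chain between the sulfonyl and the amine nitrogen remains an open question.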